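Aminomethyl on the core of the secondary amide compound 1

This account rests on a few compounds, and the source may have more. Where it says the series, first, only, none or still open, it means among the compounds named here.

Compound 1 `O=C(NCc1cc(C(F)(F)F)cc(C(F)(F)F)c1)c1cnc2ccccc2c1-c1ccccc1` carries the secondary amide. In an in vitro assay on UC11MG cells for binding affinity to Substance-P receptor (Homo sapiens), read by radioligand binding (a higher number here means a weaker inhibitor, a lower number a stronger inhibitor), compound 1 gives only a limit, > 1000 nM, and nothing more precise is known of it (the limit of > 1000 nM in this assay, at which 1 of the 3 values shown sits). Compound 2 `CN(Cc1cc(C(F)(F)F)cc(C(F)(F)F)c1)C(=O)c1cnc2ccccc2c1-c1ccccc1` differs by methyl in place of hydrogen on the amide-type nitrogen and gives 0.03 nM in this assay; that step is an at least 33000-fold lower number from compound 1 to compound 2 (4.52 log units; beyond the scatter). Compound 3 `CN(Cc1cc(C(F)(F)F)cc(C(F)(F)F)c1)C(=O)c1c(CBr)nc2ccccc2c1-c1ccccc1` adds bromomethyl on an aromatic carbon of the core and gives 52 nM in this assay; that step is a 1700-fold higher number from compound 2 to compound 3 (3.24 log units; beyond the scatter).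

Compound 4 `NCc1nc2ccccc2c(-c2ccccc2)c1C(=O)NCc1cc(C(F)(F)F)cc(C(F)(F)F)c1` is not yet measured. It differs from compound 1 by aminomethyl in place of hydrogen on an aromatic carbon, the same place where compound 3 carries bromomethyl. The step from compound 2 to compound 3 shows that a substituent at this place raised the number strongly, and compound 1 already sits at the limit. For compound 4 the expected step is a step that the limit leaves unreadable from compound 1 to compound 4. Compound 4 is estimated at 3000 nM, with a range from 500 nM to 30000 nM, in this assay. A limit rather than a number is again the likely outcome.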

Compound 4, half-maximal inhibitory concentration: 0.0017 nM
For compound 4 the middle estimate is 1800000-fold (6.25 log units) above the measured one; the whole stated range lies above it.
By their numbers in this assay, from the lowest: compound 4; then compound 2; then compound 3. At a limit, above all of these: compound 1.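

In this assay, aminomethyl on the aromatic carbon next to the ring nitrogen gives an at least 580000-fold lower number from compound 1 to compound 4 (5.76 log units; beyond the scatter), so a substituent at this place does not always raise the number, as the bromomethyl step alone, a 1700-fold higher number from compound 2 to compound 3 (3.24 log units; beyond the scatter), might have implied. Compound 4 keeps the amide hydrogen and still reaches 0.0017 nM, so the secondary amide does not by itself hold the number high. Compound 1 is a limit and not a number, so the size of the aminomethyl step is only a bound: the limit of > 1000 nM in this assay, at which 1 of the 4 values shown sits.

Going by these compounds, the two steps at this place start from different amides, so how aminomethyl behaves with the methyl on the amide nitrogen of compound 2 remains open. Also open, on these data alone, is whether a hydroxymethyl group, a longer aminoethyl chain or a dimethylaminomethyl group at this place would give a comparable step.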